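Aryl variation on the sulfonamide nitrogen: towards compound 4

This account rests on a few compounds, and the source may have more. Where it says the series, first, only, none or still open, it means among the compounds named here.

Of the compounds shown here, three have been measured in an ADME assay on the whole organism for pharmacokinetics, with Homo sapiens as the target; on this read-out higher numbers stand for higher oral bioavailability and lower numbers for lower oral bioavailability. Compound 1 `O=[N+]([O-])c1cccc(NS(=O)(=O)c2ccc3nc(-c4ccccc4)c(-c4ccccc4)nc3c2)c1` gives 85.6%; compound 2 `O=S(=O)(Nc1cccc2ccccc12)c1ccc2nc(-c3ccccc3)c(-c3ccccc3)nc2c1` gives 100%; compound 3 `CC(=O)c1cccc(NS(=O)(=O)c2ccc3nc(-c4ccccc4)c(-c4ccccc4)nc3c2)c1` gives 96.9%. Compound 3 stands second highest of the three: against compound 2 the gap is within the scatter, a number 3.1 percentage points lower from compound 2 to compound 3 (within the scatter), whereas against compound 1 it lies beyond it, a number 11.3 percentage points higher from compound 1 to compound 3 (beyond the scatter). The remaining measured step, a number 14.4 percentage points higher from compound 1 to compound 2 (beyond the scatter), is likewise modest.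

Compound 4 `O=C(O)c1ccccc1NS(=O)(=O)c1ccc2nc(-c3ccccc3)c(-c3ccccc3)nc2c1` differs from compound 3 in one place: 2-carboxyphenyl in place of 3-acetylphenyl on a sulfonamide nitrogen. Within the data shown here, the one measured step that swaps the whole aryl group on the sulfonamide nitrogen without involving a nitro group, a number 3.1 percentage points lower from compound 2 to compound 3 (within the scatter), stays within the scatter; both steps beyond the scatter set out from the nitro compound 1. Among the measured compounds shown here, no measured step introduces a carboxyphenyl group, so the data give no direction for this particular change. The expectation for compound 4 is therefore a step within the scatter, a number 6.9 percentage points lower from compound 3 to compound 4 (within the scatter). Compound 4 is estimated at 90%, with a range from 70% to 100%.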

Compound 4, oral bioavailability: 83.6%
Estimate against measurement, compound 4: 6.4 percentage points above; the range from low to high includes it.
By their numbers in this assay, from the lowest: compounds 4 and 1 (each within the scatter of the next); then compounds 3 and 2 (each within the scatter of the next).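

In this assay steps beyond the scatter on the sulfonamide nitrogen no longer all set out from compound 1: 2-carboxyphenyl gives such a step against both 3-acetylphenyl (a number 13.3 percentage points lower from compound 3 to compound 4 (beyond the scatter)) and naphthalen-1-yl (a number 16.4 percentage points lower from compound 2 to compound 4 (beyond the scatter)). Against 3-nitrophenyl it stays within the scatter (a number 2 percentage points lower from compound 1 to compound 4 (within the scatter)), so the four compounds now fall into two pairs, compound 1 with compound 4 and compound 2 with compound 3, with every step between the pairs beyond the scatter. Nothing measured here accounts for this result.

The change from 3-acetylphenyl to 2-carboxyphenyl alters both the group and where it sits, so the compounds shown do not separate these two effects. Also open, going by these compounds, is whether a methyl ester, a primary amide or an amine in place of the carboxylic acid would give a step of the same size.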